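Biphenyl for Nitrophenyl on a Core That Shows Only Limits

The source may hold more compounds than are shown below. What is called first, only, known or untested is meant among the compounds shown, and "the series" means these compounds.

Compound 1 `CSCC[C@H](NC(=O)c1ccc(NCc2cncn2Cc2ccccc2C)cc1-c1ccccc1)C(=O)O`, compound 2 `CSCC[C@H](NC(=O)c1ccc(NCc2cncn2Cc2cccc(Cl)c2)cc1-c1ccccc1)C(=O)O` and compound 3 `COC(=O)[C@H](CCSC)NC(=O)c1ccc(NCc2cncn2Cc2cccc([N+](=O)[O-])c2)cc1-c1ccccc1` share one core. In a functional assay on NIH3T3 cells (Mus musculus) (a higher number here means that more compound is needed for the effect, a lower number that less compound is needed), compound 1 gives > 10 uM, which is a limit of the assay. Compound 2 likewise gives only the limit > 10 uM in this assay. Compound 3 also stops at the limit > 10 uM in this assay, so its standing is known only as a limit. Among the measured compounds shown here, the step that the two limits leave unreadable from compound 1 to compound 2 therefore cannot be read, and the sole evidence is the limit of > 10 uM in this assay, at which 3 of the 3 values shown sit. Compound 4 `COC(=O)[C@H](CCSC)NC(=O)c1ccc(NCc2cncn2Cc2ccc(-c3ccccc3)cc2)cc1-c1ccccc1` differs from compound 3 by 4-phenylphenyl in place of 3-nitrophenyl on a saturated chain carbon bound to an aromatic nitrogen. No readable step bears on this change, so no shift beyond the scatter can be expected in this assay. Compound 4 is accordingly estimated at 15 uM, between 5 uM and 50 uM. The step that the limit leaves unreadable from compound 3 to compound 4 that this estimate implies is expected to stay within the scatter.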

Compound 4, concentration for half-maximal effect: > 10 uM
Compound 4: no number, only a limit; the forecaster's own chance of this, stated with the estimate: 75%; the middle value is on the limit's open side.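

In this assay compound 4 gives only the limit > 10 uM and compound 3 also gives only a limit, so the step between these two compounds cannot be read. The compounds shown leave open what concentration any of them actually needs for the effect: the limit of > 10 uM in this assay, at which 4 of the 4 values shown sit.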